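The source may hold more compounds than are shown below. What is called first, only, known or untested is meant among the compounds shown, and "the series" means these compounds.

Measured so far in a functional assay on the whole organism for inhibition, with Rattus norvegicus as the target, read by cytopathic effect and paw edema, at a dose of 100 mg/kg by the oral route; a higher number here means more inhibition at the dose given (going by the name of the read-out), a lower number less inhibition:
- compound 1 `O=C(Nc1cccc(Cl)c1)c1c(O)c2cccnc2n(-c2ccccc2)c1=O` gives 13.4%
- compound 2 `Cc1ccccc1NC(=O)c1c(O)c2cccnc2n(-c2ccccc2)c1=O` gives 9.8%
- compound 3 `O=C(Nc1cccnc1)c1c(O)c2cccnc2n(-c2ccccc2)c1=O` gives 30.8%

Compound 3 stands highest of the three: the step of a number 17.4 percentage points higher from compound 1 to compound 3 (beyond the scatter) and the step of a number 21 percentage points higher from compound 2 to compound 3 (beyond the scatter) both lie beyond the scatter, while the step of a number 3.6 percentage points lower from compound 1 to compound 2 (within the scatter) does not. Within the data shown here, all three compounds share one core and differ only in the ring carried on the amide-type nitrogen, so the numbers so far say that swapping this ring can move the read-out by a modest amount.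

Compound 4 `O=C(Nc1cnccn1)c1c(O)c2cccnc2n(-c2ccccc2)c1=O` follows the same line. Its change from compound 3 is pyrazin-2-yl in place of pyridin-3-yl on an amide-type nitrogen. The two steps into compound 3 replaced a carbon-only six-membered ring by a ring holding one nitrogen; the present change keeps a nitrogen-bearing ring and adds a second nitrogen. Among the measured compounds shown here, no measured pair contains pyrazin-2-yl, so there is no direct guide, and the steps that do bear on it show modest sizes at most. A step no larger than those, in either direction, is therefore expected, and the estimate is placed close to compound 3 with a wide range. For compound 4 the expected value is 27%, between 10% and 44%, which means an expected step of a number 3.8 percentage points lower from compound 3 to compound 4 (within the scatter).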

Compound 4, a percentage reported as inhibition, in the whole organism at one dose (the size of the read-out at that dose, not a potency): 21.2%
The estimate for compound 4 lay 5.8 percentage points above the measured number; low and high end bracket the measured number.
By their numbers in this assay, from the lowest: compounds 2, 1, 4 and 3 (each within the scatter of the next, the first and the last beyond it).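

Going from one ring nitrogen to two, with pyrazin-2-yl in place of pyridin-3-yl, gives a number 9.6 percentage points lower from compound 3 to compound 4 (within the scatter) in this assay, so the second nitrogen produces no step that can be told apart from the usual scatter. The comparison with the carbon-only rings is split: pyrazin-2-yl in place of 2-methylphenyl gives a number 11.4 percentage points higher from compound 2 to compound 4 (beyond the scatter), while pyrazin-2-yl in place of 3-chlorophenyl gives a number 7.8 percentage points higher from compound 1 to compound 4 (within the scatter), so a nitrogen-bearing ring at this position does not separate clearly from both carbon-only rings in every case. No measurement at hand offers a reason for these steps.

Going by these compounds, how pyridin-4-yl or pyridin-2-yl on the same amide-type nitrogen would compare remains open. So does whether an aromatic ring is needed there at all, or whether a saturated cyclohexyl ring or a plain butyl chain would serve.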